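This account rests on a few compounds, and the source may have more. Where it says the series, first, only, none or still open, it means among the compounds named here.

In a physicochemical assay for solubility, read by nephelometry, measured as kinetic solubility, with a stated time of 30 min (on this read-out higher numbers stand for higher solubility and lower numbers for lower solubility), compound 1 `c1cc([C@H]2CC[C@]3(CC2)OOC2(O3)C3CC4CC(C3)CC2C4)ccc1OCCOC1CCNCC1` gives 50 ug/mL. Compound 2 `c1cc([C@H]2CC[C@]3(CC2)OOC2(O3)C3CC4CC(C3)CC2C4)ccc1OCCC1CCNCC1` gives only a limit, > 100 ug/mL. Compound 3 `CC1(C)CC(O)(COc2ccc([C@H]3CC[C@]4(CC3)OOC3(O4)C4CC5CC(C4)CC3C5)cc2)CC(C)(C)N1` likewise gives only a limit, > 100 ug/mL.

For the measured compounds named here, compound 1 thus holds the sole numerical value, the other two readings sitting at the limit of > 100 ug/mL in this assay, at which 2 of the 3 values shown sit. Compound 4 `O[C@H]1CC[C@H](NCCCOc2ccc([C@H]3CC[C@]4(CC3)OOC3(O4)C4CC5CC(C4)CC3C5)cc2)CC1` differs from compound 1 by ((4-hydroxycyclohexyl)amino)methyl in place of (piperidin-4-yl)oxy on a saturated chain carbon, two bonds along the chain from an oxygen on an aromatic ring. Going by the values given here, two measured steps bear on this: an at least 2.0-fold higher number from compound 1 to compound 2 (0.30 log units; that floor lies within the scatter) and an at least 2.0-fold higher number from compound 1 to compound 3 (0.30 log units; that floor lies within the scatter), both changes at the same chain carbon moving the reading to the limit. A rise from compound 1 to compound 4 of comparable size is therefore expected, a 2.0-fold higher number from compound 1 to compound 4 (0.30 log units; within the scatter), with a fair chance that this assay again reports only a limit. For compound 4 the estimated solubility is 100 ug/mL, ranging from 50 ug/mL to 200 ug/mL.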

Compound 4, solubility: > 100 ug/mL
Compound 4 gave a limit, no number; the forecaster's own chance of this, stated with the estimate: 50%; the middle value sits exactly at the limit.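

In this assay, compound 4 gives only a limit, > 100 ug/mL. Placing ((4-hydroxycyclohexyl)amino)methyl on this chain carbon, with its six-membered ring of carbon only, gives an at least 2.0-fold higher number from compound 1 to compound 4 (0.30 log units; that floor lies within the scatter), so this change holds without a piperidine ring. The steps among compound 2, compound 3 and compound 4 cannot be read, and compound 1 remains the only compound with a number: the limit of > 100 ug/mL in this assay, at which 3 of the 4 values shown sit.

From the compounds shown here alone, how far these three compounds lie past the limit stays open, so they cannot be ranked. Also open, going by these compounds, is how a carboxylic acid or a longer chain would read at this chain carbon.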